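The source may report more compounds than this note shows. Statements on the series, on what has been measured and on what is new or still open speak of the compounds shown alone.

Measured so far in a functional assay on HEK293 cells for agonist activity at Toll-like receptor 8 (Homo sapiens), read by reporter gene assay; on this read-out higher numbers stand for an effect only at larger amounts of compound and lower numbers for an effect already at smaller amounts:
compound 1 `CCCCNc1oc2c(C)ncc(CO)c2c1Nc1ccccn1`: 9380 nM
compound 2 `CCCC(C)Nc1oc2c(C)ncc(CO)c2c1Nc1ccccn1`: 9010 nM
compound 3 `Cc1ncc(CO)c2c(Nc3ccccn3)c(NC(C)(C)CC(C)(C)C)oc12`: "not active" (no number reported)

Going by the values given here, compound 1 and compound 2 sit close together; the step of a 1.0-fold lower number from compound 1 to compound 2 (0.02 log units; within the scatter) is the only one between measured compounds that differ in one place. Compound 3 stands apart from both, with no numerical value in this assay at all.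

Compound 4 `Cc1ncc(CO)c2c(Nc3ccccn3)c(NCCC(=O)OC(C)(C)C)oc12` differs from compound 3 by 2-(tert-butoxycarbonyl)ethyl in place of 1,1,3,3-tetramethylbutyl on a nitrogen on an aromatic ring. Among the compounds with values here, no measured step covers this change. Within the data shown here, the one measured step, a 1.0-fold lower number from compound 1 to compound 2 (0.02 log units; within the scatter), concerns a different alteration on the same nitrogen and lay within the scatter, so it gives little guidance. Compound 4, like compound 1 and compound 2, carries an unbranched chain on that nitrogen, whereas compound 3 carries the branched 1,1,3,3-tetramethylbutyl and is without a number. Compound 4 is therefore expected to land near compound 1 and compound 2, with an estimated value of 10000 nM and a range from 3000 nM to 40000 nM, with a real chance that only a limit is reported as for compound 3.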

Compound 4, half-maximal effective concentration: 7640 nM
Compound 4: the middle estimate sits 1.3-fold (0.12 log units) above what was measured; the range from low to high includes it.
By their numbers in this assay, from the lowest: compounds 4, 2 and 1 (each within the scatter of the next).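

In this assay, the nitrogen on an aromatic ring tolerates 2-(tert-butoxycarbonyl)ethyl with no change beyond the scatter: a 1.2-fold lower number from compound 2 to compound 4 (0.07 log units; within the scatter), and a 1.2-fold lower number from compound 1 to compound 4 (0.09 log units; within the scatter). A chain ending in tert-butoxycarbonyl, with its two hydrogen-bond acceptors, therefore still gives a number, whereas compound 3, with 1,1,3,3-tetramethylbutyl at the same place, gives none. No measurement on hand explains this difference.

Going by these compounds, whether a carboxylic acid or an amine at the chain end would give a similar number remains open. So does the effect of a longer chain at this nitrogen.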